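The source may hold more compounds than are shown below. What is called first, only, known or untested is meant among the compounds shown, and "the series" means these compounds.

Of the compounds shown here, two have been measured so far in an ADME assay on MT4 cells (Homo sapiens) for cytotoxicity, read by MTT assay, with a stated time of 96 h; a higher number here means that more compound is tolerated, a lower number that less compound is tolerated. Compound 1 `Cc1ccccc1C1CC(c2ccc(OCc3ccccc3)cc2)=NN1c1ccc(S(N)(=O)=O)cc1` gives >= 100000 nM, which is a limit of the assay and not a number. Its standing is therefore known only as the limit of >= 100000 nM in this assay, at which 1 of the 2 values shown sits. The other measured compound, compound 2 `Cc1cccc(C2CC(c3ccc(Oc4ccccc4)cc3)=NN2c2ccc(S(N)(=O)=O)cc2)c1`, gives a true number of 35000 nM in this assay.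

The next compound, compound 3 `NS(=O)(=O)c1ccc(N2N=C(c3ccc(OCc4ccccc4)cc3)CC2c2ccccc2Cl)cc1`, keeps the rest of compound 1 and makes a single exchange, (chloro in place of methyl on an aromatic carbon). This places chloro in place of methyl on an aromatic carbon, ortho to a large group, turning 2-methylphenyl to 2-chlorophenyl. Within the data shown here, no measured pair shows this exchange, so the expectation is a cautious one. The estimated step of an at least 1.4-fold lower number from compound 1 to compound 3 (0.15 log units; that floor lies within the scatter) in this assay is expected to stay within the scatter. Any lean would be towards less compound being tolerated, and that lean rests only on compound 2 at 35000 nM. The assay may well report only a limit again. For compound 3 the expected half-maximal cytotoxic concentration is 70000 nM, with an estimated range from 30000 nM to 100000 nM.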

Compound 3, half-maximal cytotoxic concentration: 26000 nM
The estimate for compound 3 lay 2.7-fold (0.43 log units) above the measured number; measured number below the stated range.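

The exchange of methyl for chloro on an aromatic carbon, ortho to a large group, comes with an at least 3.8-fold lower number from compound 1 to compound 3 (0.58 log units; beyond the scatter) in this assay, so this position does respond to the change from 2-methylphenyl to 2-chlorophenyl. Among these compounds, until now no pair of compounds differing in one place had been available, and this is the first step that can be read directly, with the rest of the structure held constant. The size of that step remains a floor and not a full measure because the reading for compound 1 is a limit of the assay and not a number: the limit of >= 100000 nM in this assay, at which 1 of the 3 values shown sits.

The compounds shown hold only methyl and chloro at this place, so how a fluoro, a methoxy or an amine there would read in this assay remains open, as does whether the step depends on the chloro group itself or would be shared by other replacements. Compound 2 differs from compound 1 and compound 3 in more than one place, so it cannot show whether the same exchange would give a similar step on another version of the shared core.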